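The source may report more compounds than this note shows. Statements on the series, on what has been measured and on what is new or still open speak of the compounds shown alone.

Of the compounds shown here, two of one shared core have been measured in an assay on cells for inhibition of Voltage-dependent T-type calcium channel subunit alpha-1H (Homo sapiens), read by patch clamp, tested at 10 uM; on this read-out lower numbers stand for less inhibition and higher numbers for more inhibition at the one concentration tested (going by the name of the read-out). Compound 1, `CN(C)CCCCCSC1=Nc2ccccc2C(CC(=O)NCc2ccccc2)N1c1ccc(-c2ccc(F)cc2)cc1`, gives 75.6% in this assay. Compound 2, `O=C(CC1c2ccccc2N=C(SCCCCCN2CCCC2)N1c1ccc(-c2ccccc2)cc1)NCc1ccc(F)cc1`, gives 69% in this assay, and this number sits within the scatter of the number for compound 1, so the two cannot be set in order.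

Compound 3, `O=C(CC1c2ccccc2N=C(SCCCCCN2CCCC2)N1c1ccc(-c2ccc(F)cc2)cc1)NCc1ccc(F)cc1`, has not yet been measured. It differs from compound 2 in one place: fluoro in place of hydrogen on an aromatic carbon. Going by the values given here, no pair of measured compounds shows this difference on its own, so there is no measured step to go by. The pair of compound 1 and compound 2 suggests that moving a fluoro between the rings of this core leaves the inhibition roughly where it was. The step is expected to be a number 3 percentage points higher from compound 2 to compound 3 (within the scatter), that is, no change beyond the scatter. Compound 3 is therefore estimated at 72%, with a range from 55% to 86%.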

Compound 3, a percentage reported as inhibition, at one concentration (the size of the read-out at that concentration, not a potency): 76.6%
The estimate for compound 3 lay 4.6 percentage points below the measured number; the measured number falls inside the stated range.
By their numbers in this assay, from the lowest: compounds 2, 1 and 3 (each within the scatter of the next).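

In this assay, going by these compounds alone, compound 2 and compound 3 form the first measured pair that differs in this one place, and the step is a number 7.6 percentage points higher from compound 2 to compound 3 (within the scatter) on going from phenyl to 4-fluorophenyl. Fluoro in place of hydrogen on this aromatic carbon, para to a large group, therefore leaves the inhibition at the one concentration tested without a change beyond the scatter, and this holds with the pyrrolidine chain and the fluoro on the amide side in place. Nothing measured here gives a reason for this result.

Going by these compounds, it stays open whether a chloro, a methoxy or a carboxylic acid at this position would also leave the inhibition unchanged. On these data alone, it also stays open whether the same change would give a similar step with the dimethylamino chain of compound 1.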